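The source may report more compounds than this note shows. Statements on the series, on what has been measured and on what is new or still open speak of the compounds shown alone.

Within the data shown here, the three measured members, all built on the shared core, were judged in a functional assay (strain AB) with Danio rerio as the target, read by microscopy, with a stated time of 1 h; a lower number here means that less compound is needed, a higher number that more compound is needed for the effect. Compound 1, `CCN1CCc2c(sc(N)c2C(N)=O)C1`, reaches only a limit in this assay, > 25000 nM, which is what the limit of > 25000 nM in this assay, at which 1 of the 3 values shown sits, records. Compound 2, `CC(C)(C)C[N+]1(C)CCc2c(sc(NC(=O)Nc3ccc(Cl)cc3)c2C(N)=O)C1`, gives 290 nM in this assay. Compound 3, `CC(C)CN1CCc2c(sc(NC(=O)Nc3ccc(Cl)cc3)c2C(N)=O)C1`, gives 4510 nM in this assay, the highest of the two numbers, and its gap to compound 2 lies beyond the scatter. Compound 4, `NC(=O)c1c(NC(=O)Nc2ccc(Cl)cc2)sc2c1CCN(CC1CCC1)C2`, differs from compound 3 by cyclobutyl in place of isopropyl on a saturated chain carbon bound to an amine nitrogen in a ring. Among the measured compounds shown here, no measured pair shows this change, so for compound 4 a step in this assay of modest size, or none beyond the scatter, is expected. Compound 4 is estimated at 3000 nM, in the range 1000 nM to 10000 nM. That estimate means an expected step of a 1.5-fold lower number from compound 3 to compound 4 (0.18 log units; within the scatter).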

Compound 4, half-maximal effective concentration: 1360 nM
Compound 4: the middle estimate sits 2.2-fold (0.34 log units) above what was measured; the range from low to high includes it.
By their numbers in this assay, from the lowest: compound 2; then compound 4; then compound 3. At a limit, above all of these: compound 1.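

At the place on a saturated chain carbon bound to an amine nitrogen in a ring, cyclobutyl in place of isopropyl brings a 3.3-fold lower number from compound 3 to compound 4 (0.52 log units; beyond the scatter) in this assay and so shows that this position responds to a small change in the carbon group. Among these compounds, this is the first step between compounds that differ in one place, so the earlier compounds could not show this. Nothing measured here bears on why the number moves. On these data alone, whether a cyclopentyl group or a longer chain at this place would move the number further remains open. So does the effect of a hydroxyl group or a carboxylic acid on the cyclobutyl ring.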